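A few compounds are considered here, and "the series" means these few. Any claim that something is new, unique, unknown or untested is made for them only; others in the source may bear on it.

Compound 1 `C=C1CC[C@@H]2[C@](C)(CO)[C@H](O)CC[C@@]2(C)[C@@H]1CC(Sc1ccc(OC)cc1)C1=CCOC1=O`: 15000 nM
Compound 2 `C=C1CC[C@@H]2[C@](C)(CO)[C@H](O)CC[C@@]2(C)[C@@H]1C/C=C1/C(=O)OC[C@H]1OC(=O)CSc1ccc([N+](=O)[O-])cc1`: 17000 nM
Compound 3 `C=C1CC[C@@H]2[C@](C)(CO)[C@H](O)CC[C@@]2(C)[C@@H]1C/C=C1/C(=O)OC[C@H]1OC(=O)CSc1ccc(C)cc1`: 27000 nM

In a functional assay on PC-3 cells (Homo sapiens) for inhibition, read by MTT assay, with a stated time of 48 h (on this read-out higher numbers stand for weaker inhibition and lower numbers for stronger inhibition), compound 3 gives the highest of the three numbers, but its gaps to compound 2 and to compound 1 both lie within the scatter, so the three measured compounds stand together. Within the data shown here, the only single-point step known is a 1.6-fold higher number from compound 2 to compound 3 (0.20 log units; within the scatter), which did not move the read-out beyond the scatter. Compound 4 `C=C1CC[C@@H]2[C@](C)(CO)[C@H](O)CC[C@@]2(C)[C@@H]1C/C=C1/C(=O)OC[C@H]1OC(=O)CSc1cccs1` differs from compound 3 by thiophen-2-yl in place of 4-methylphenyl on a sulfur. Among the measured compounds shown here, that step touches the same aromatic end of the side chain as the measured step, and nothing among the measured compounds suggests that a change there shifts the numbers. The step from compound 3 to compound 4 is therefore expected to be a 1.2-fold lower number from compound 3 to compound 4 (0.09 log units; within the scatter), no more than the scatter. Compound 4 is estimated at 22000 nM, within a range of 11000 nM to 45000 nM.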

Compound 4, half-maximal inhibitory concentration: 18000 nM
Beside the measured number, compound 4's estimate is 1.2-fold (0.09 log units) above it; measured number inside the range.
By their numbers in this assay, from the lowest: compounds 1, 2, 4 and 3 (each within the scatter of the next).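

In this assay, putting a five-membered aromatic ring with a hetero atom on the sulfur in place of a six-membered carbon ring leaves the read-out within the scatter, with a 1.5-fold lower number from compound 3 to compound 4 (0.18 log units; within the scatter) and a 1.1-fold higher number from compound 2 to compound 4 (0.02 log units; within the scatter). So among these compounds, not only the group carried on the aromatic ring but the ring itself can differ without the number moving beyond the scatter. Nothing available explains this flat response.

Going by these compounds, it remains open whether an amine or a carboxylic acid on the aromatic ring, or a cyclohexyl group in its place, would move the number beyond the scatter.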